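Replacing 3-(trifluoromethyl)phenyl with 1-carboxyethyl on an amide

The compounds below may be only part of what the source reports. "The series", "measured", "known", "first", "only" and "open" are said of these compounds alone.

In an ADME assay on L02 cells (Homo sapiens) for antiproliferative activity, read by MTT assay, with a stated time of 48 h (a lower number here means a stronger inhibitor, a higher number a weaker inhibitor), compound 2 `CCn1c(C(=O)Nc2cccc(C(F)(F)F)c2)ccc1C(CC)(CC)c1ccc(OCCC(O)(CC)CC)c(C)c1` gives > 50000 nM, which is a limit of the assay and not a number. Compound 1 `C#CC(C)OC(=O)c1ccc(C(CC)(CC)c2ccc(OCCC(O)(CC)CC)c(C)c2)n1CC` also gives only a limit, > 50000 nM. Compound 2 therefore stands at the limit of > 50000 nM in this assay, at which 2 of the 3 values shown sit. Among the measured compounds shown here, the only true number so far comes from compound 3 `CCn1c(C(=O)N(C)CC(=O)O)ccc1C(CC)(CC)c1ccc(OCCC(O)(CC)CC)c(C)c1`, which gives 2150 nM.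

The next candidate is compound 4 `CCn1c(C(=O)NC(C)C(=O)O)ccc1C(CC)(CC)c1ccc(OCCC(O)(CC)CC)c(C)c1`, which carries 1-carboxyethyl in place of 3-(trifluoromethyl)phenyl on an amide-type nitrogen. The nearest measured change is an at least 23-fold lower number from compound 2 to compound 3 (1.36 log units; beyond the scatter), where (carboxymethyl)(methyl)amino replaces (3-(trifluoromethyl)phenyl)amino on a carbonyl carbon. A second change, an at least 23-fold lower number from compound 1 to compound 3 (1.36 log units; beyond the scatter), ends at the same compound. For the measured compounds named here, the group in compound 4 is not the same as the one in compound 3, but both names contain a carboxy unit, so compound 3 is the best guide available.

A large step to a lower number is therefore expected in this assay, though a single compound is thin support. The expected change is an at least 12-fold lower number from compound 2 to compound 4 (1.09 log units; beyond the scatter). The estimated value for compound 4 is 4000 nM, with an expected range from 1000 nM to 20000 nM.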

Compound 4, half-maximal inhibitory concentration: 4040 nM
The estimate for compound 4 lay 1.0-fold (0.00 log units) below the measured number; the measured number falls inside the stated range.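

Placing 1-carboxyethyl on the amide-type nitrogen, in place of 3-(trifluoromethyl)phenyl, gives a second true number in this assay, with an at least 12-fold lower number from compound 2 to compound 4 (1.09 log units; beyond the scatter) and likewise an at least 12-fold lower number from compound 1 to compound 4 (1.09 log units; beyond the scatter). The two carboxy-bearing groups then read alike, with a 1.9-fold higher number from compound 3 to compound 4 (0.27 log units; within the scatter), so swapping (carboxymethyl)(methyl)amino for (1-carboxyethyl)amino on the carbonyl carbon makes no readable difference, and among these four compounds only the two with a carboxy unit give a true number, with no compound going against this. Going by these compounds, both large steps are minimum sizes, since they start from limits and not from numbers, and the true distance remains unknown; for compound 2 the position is this: the limit of > 50000 nM in this assay, at which 2 of the 4 values shown sit.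

These compounds cannot separate the carboxylic acid from the rest of the new group, and a methyl ester of 1-carboxyethyl or a 2-aminoethyl group on the same nitrogen would put that question directly. They also leave open how a longer chain, such as 3-carboxypropyl, would read in this assay, and whether the small branch of 1-carboxyethyl matters at all compared with a plain carboxymethyl group on the same nitrogen.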